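This account rests on a few compounds, and the source may have more. Where it says the series, first, only, none or still open, it means among the compounds named here.

Working notes on a hydrazone series built on the core of compound 1 `O=C(CSc1nnc(-c2ccncc2)o1)N/N=C/c1ccc(O)cc1`, tested in a functional assay on BGC-823 cells (Homo sapiens) for cytotoxicity, read by MTT assay, with a stated time of 48 h (on this read-out lower numbers stand for stronger inhibition and higher numbers for weaker inhibition), where compound 1 gives 7940 nM. Compound 2 `COc1ccc(/C=N/NC(=O)CSc2nnc(-c3ccncc3)o2)cc1` carries the change methyl in place of hydrogen on an oxygen on an aromatic ring and in this assay compound 2 gives 19800 nM, a step of a 2.5-fold higher number from compound 1 to compound 2 (0.40 log units; beyond the scatter). Compound 3 `O=C(CSc1nnc(-c2ccncc2)o1)N/N=C/c1ccc(O)c(O)c1` differs from compound 1 by hydroxy in place of hydrogen on an aromatic carbon, and in this assay compound 3 gives 1260 nM, the lowest number of the three measured, with a 6.3-fold lower number from compound 1 to compound 3 (0.80 log units; beyond the scatter) and a 16-fold lower number from compound 2 to compound 3 (1.20 log units; beyond the scatter). Compound 4 `COc1cc(/C=N/NC(=O)CSc2nnc(-c3ccncc3)o2)ccc1O` is not yet measured; it differs from compound 3 by methyl in place of hydrogen on an oxygen on an aromatic ring. This is the same change as that from compound 1 to compound 2, the place reading identically in both, though one bond further out the earlier case reads 4-hydroxyphenyl to 4-methoxyphenyl and the present case 3,4-dihydroxyphenyl to 4-hydroxy-3-methoxyphenyl. The expected step is a 3.6-fold higher number from compound 3 to compound 4 (0.55 log units; beyond the scatter) in this assay, somewhat larger than a 2.5-fold higher number from compound 1 to compound 2 (0.40 log units; beyond the scatter), resting on that earlier step and on the fact that compound 3 gives 1260 nM only as the 3,4-dihydroxyphenyl member. In this assay compound 4 is estimated at 4500 nM, expected to fall between 1500 nM and 13000 nM.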

Compound 4, half-maximal inhibitory concentration: 4320 nM
Compound 4: the middle estimate sits 1.0-fold (0.02 log units) above what was measured; the measured number falls inside the stated range.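

In this assay, methyl in place of hydrogen on an oxygen on an aromatic ring gives a 3.4-fold higher number from compound 3 to compound 4 (0.54 log units; beyond the scatter), and the change carries over between the two cores with no difference beyond the scatter: the same change on two cores in this assay, a 2.5-fold higher number (0.40 log units; beyond the scatter) from compound 1 to compound 2 and a 3.4-fold higher number (0.54 log units; beyond the scatter) from compound 3 to compound 4, 1.4-fold (0.14 log units) apart, within the scatter of two such steps. This does not show a general rule: it rests on two pairs in one assay, and the names differ, with 4-hydroxyphenyl going to 4-methoxyphenyl in one pair and 3,4-dihydroxyphenyl going to 4-hydroxy-3-methoxyphenyl in the other. The other new steps are a 4.6-fold lower number from compound 2 to compound 4 (0.66 log units; beyond the scatter) and a 1.8-fold lower number from compound 1 to compound 4 (0.26 log units; within the scatter), so the 4-hydroxy-3-methoxyphenyl and 4-hydroxyphenyl members are not separated in this assay.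

The compounds shown leave open whether a longer chain on the same oxygen, such as ethoxy, would follow the same step. They also leave open what an amine or a carboxylic acid on the aromatic ring in place of a hydroxy would give.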